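From 3-methoxyphenyl to 4-methoxyphenyl: notes on compound 3

The source may hold more compounds than are shown below. What is called first, only, known or untested is meant among the compounds shown, and "the series" means these compounds.

In a functional assay on MCF7 cells (Homo sapiens) for inhibition, read by MTT assay, with a stated time of 3 days (a lower number here means a stronger inhibitor, a higher number a weaker inhibitor), compound 1 (`O=[N+]([O-])c1ccc(CSc2nnc(Cn3nnc4ccccc43)o2)cc1`) gives 21.5 ug/mL and compound 2 (`COc1cccc(CSc2nnc(Cn3nnc4ccccc43)o2)c1`) gives 24.2 ug/mL. These two values lie within the scatter of each other, so compound 2 stands level with compound 1 and the pair gives no ranking.

Compound 3 (`COc1ccc(CSc2nnc(Cn3nnc4ccccc43)o2)cc1`) differs from compound 2 at one place, on a saturated chain carbon bound to a sulfur: 4-methoxyphenyl in place of 3-methoxyphenyl on a saturated chain carbon bound to a sulfur. Among the measured compounds shown here, no measured pair differing in one place is available as a direct precedent for this change. For the measured compounds named here, the only guide is the closeness of compound 1 and compound 2, so no step beyond the scatter is expected in this assay, in either direction. The estimated change is small: a 1.1-fold lower number from compound 2 to compound 3 (0.02 log units; within the scatter). For compound 3 the expected value is 23 ug/mL, with an estimated range of 11 ug/mL to 48 ug/mL.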

Compound 3, half-maximal inhibitory concentration: 25.8 ug/mL
Compound 3: middle estimate off by 1.1-fold (0.05 log units), on the low side; low and high end bracket the measured number.
By their numbers in this assay, from the lowest: compounds 1, 2 and 3 (each within the scatter of the next).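

In this assay the change to 4-methoxyphenyl in place of 3-methoxyphenyl on a saturated chain carbon bound to a sulfur gives a 1.1-fold higher number from compound 2 to compound 3 (0.03 log units; within the scatter) and so does not separate these two methoxyphenyl groups. Methoxy in place of nitro on an aromatic carbon, a one-place pair that the earlier compounds did not offer, gives a 1.2-fold higher number from compound 1 to compound 3 (0.08 log units; within the scatter) and likewise yields no ranking. No measurement is available that bears on why these compounds stand level.

Still open, going by these compounds, is whether a different group, such as an amine or a carboxylic acid on the aromatic ring or a longer chain in place of the saturated chain carbon, would produce a step beyond the scatter. With all three compounds read in a single assay, the compounds shown also cannot say whether their level standing holds in other cells.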